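The compounds below may be only part of what the source reports. "The series", "measured", "known", "first", "only" and "open" are said of these compounds alone.

Compound 1 `CCCCOc1ccc(C(=O)/C=C/c2c(/C=C/c3ccc(OC)cc3)cc(OC)cc2OC)cc1`: 12.9 ug/mL
Compound 2 `CCOc1ccc(C(=O)/C=C/c2c(/C=C/c3ccc(OC)cc3)cc(OC)cc2OC)cc1`: 8 ug/mL
Compound 3 `CCCC(C)Oc1ccc(C(=O)/C=C/c2c(/C=C/c3ccc(OC)cc3)cc(OC)cc2OC)cc1`: 11.1 ug/mL

All three were measured in a functional assay on HepG2 cells (Homo sapiens) for antiproliferative activity, read by MTT assay, with a stated time of 48 h; on this read-out higher numbers stand for weaker inhibition and lower numbers for stronger inhibition. Compound 1 gives the highest of the three numbers, yet the steps of a 1.2-fold lower number from compound 1 to compound 3 (0.07 log units; within the scatter) and a 1.6-fold lower number from compound 1 to compound 2 (0.21 log units; within the scatter) both fall within the scatter, so on this read-out the three compounds cannot be told apart. Compound 4 `COc1ccc(/C=C/c2cc(OC)cc(OC)c2/C=C/C(=O)c2ccc(C)cc2C)cc1` has not been measured. It differs from compound 1 in one place: 2,4-dimethylphenyl in place of 4-butoxyphenyl on a carbonyl carbon. The steps measured so far only alter the saturated chain: a 1.6-fold lower number from compound 1 to compound 2 (0.21 log units; within the scatter), a 1.2-fold lower number from compound 1 to compound 3 (0.07 log units; within the scatter) and a 1.4-fold higher number from compound 2 to compound 3 (0.14 log units; within the scatter). None removes the oxygen or brings in methyl groups, so they bear on the new change only loosely; what they do show is that small alterations to the group on the carbonyl carbon have given no step beyond the scatter. The expected step is therefore a 1.1-fold lower number from compound 1 to compound 4 (0.03 log units; within the scatter), meaning no change beyond the scatter. As far as these compounds go, compound 4 is estimated at 12 ug/mL, within a range of 5 ug/mL to 30 ug/mL, the range being kept wide since the loss of the oxygen is untested.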

Compound 4, half-maximal inhibitory concentration: 0.9 ug/mL
For compound 4 the middle estimate is 13-fold (1.12 log units) above the measured one; measured number outside the range, below it.
By their numbers in this assay, from the lowest: compound 4; then compounds 2, 3 and 1 (each within the scatter of the next).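

In this assay the group on the carbonyl carbon proves able to shift the number far beyond the scatter: 2,4-dimethylphenyl gives a 14-fold lower number from compound 1 to compound 4 (1.16 log units; beyond the scatter) and a 12-fold lower number from compound 3 to compound 4 (1.09 log units; beyond the scatter) and also an 8.9-fold lower number from compound 2 to compound 4 (0.95 log units; beyond the scatter) while changes to the saturated chain alone had stayed within the scatter. All three steps point towards stronger inhibition, whichever of the three oxygen-linked chains leaves. For the compounds shown here, nothing available explains this result, and the single swap removes the oxygen and its chain and brings in two methyl groups all at once.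

The compounds shown leave open whether the loss of the oxygen or the arrival of the methyl groups matters more. A plain phenyl or a 4-methylphenyl group on the carbonyl carbon would help to separate the two.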